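A few compounds are considered here, and "the series" means these few. Any claim that something is new, unique, unknown or untested is made for them only; others in the source may bear on it.

Compound 1 `COc1cc(-c2cnc3c(N4CCCC(CNC(=O)C5CC5)C4)snc3c2)ccc1N` and compound 2 `COc1cc(-c2cnc3c(N4CCC[C@@H](CNC(=O)C5CC5)C4)snc3c2)ccc1N` share every atom and bond and differ only in how one saturated ring carbon is drawn. In an assay on isolated protein for binding affinity to Cyclin-G-associated kinase (Homo sapiens), read by TR-FRET and LanthaScreen, with a stated time of 1 h (a higher number here means a weaker inhibitor, a lower number a stronger inhibitor), compound 1 gives 14 nM, while compound 2 gives 360 nM, the higher of the two numbers. The step of a 26-fold higher number from compound 1 to compound 2 (1.41 log units; beyond the scatter) is linked to the fact that one of compounds 1 and 2 is drawn with a defined configuration and the other without, at the place where they differ, a mixture of forms set against a single one. Compound 3 `COc1cc(-c2cnc3c(N4CCC[C@H](CNC(=O)C5CC5)C4)snc3c2)ccc1N` differs from compound 2 only in that (the two compounds have the same atoms and bonds and differ only in configuration as drawn: 1 of 1 stereo elements differ; a stereocentre at a saturated ring carbon is drawn S in compound 2 and R in compound 3). If the mixture's stronger reading came from this other form, compound 3 is expected to move the opposite way, a 51-fold lower number from compound 2 to compound 3 (1.71 log units; beyond the scatter), to an estimated 7 nM in this assay, within a range of 3 nM to 25 nM.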

Compound 3, half-maximal inhibitory concentration: 13 nM
For compound 3 the middle estimate is 1.9-fold (0.27 log units) below the measured one, and the stated range covers the measured number.
By their numbers in this assay, from the lowest: compounds 3 and 1 (each within the scatter of the next); then compound 2.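

Changing the drawn configuration at this saturated ring carbon from S to R gives a 28-fold lower number from compound 2 to compound 3 (1.44 log units; beyond the scatter) in this assay, so the two forms at this position are clearly not equal. The R form also matches compound 1, drawn without a configuration, with a 1.1-fold lower number from compound 1 to compound 3 (0.03 log units; within the scatter). The gap between the two defined forms is tied to the stereocentre alone: the fact that compounds 2 and 3 differ only in the configuration as drawn

The compounds shown leave open how much of each form compound 1 contains. They also leave open whether R still beats S when an amine replaces the amide.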